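The source may hold more compounds than are shown below. What is called first, only, known or untested is meant among the compounds shown, and "the series" means these compounds.

Measured compounds:
compound 1, `Cc1nc(N2CCN(C3CCOCC3)CC2)nc2ccc(NC(=O)COc3ccc(Cl)cc3)cc12`, 115 nM
compound 2, `CCN1CCN(c2nc(C)c3cc(NC(=O)COc4ccc(Cl)cc4)ccc3n2)CC1`, "not determined" (no result reported)

Compound 1 carries a tetrahydropyranyl group on the piperazine and, in a functional assay on CHO-K1 cells for antagonist activity at melanin-concentrating hormone receptor 1 (Homo sapiens), read by inositol phosphate accumulation (on this read-out higher numbers stand for weaker inhibition and lower numbers for stronger inhibition), compound 1 gives 115 nM. Compound 2 carries an ethyl group in that position instead; for compound 2 the this assay returned no number at all, so compound 2 stands nowhere on the scale shown and offers no anchor of its own.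

Compound 3, `Cc1nc(N2CCN(CC(C)(C)C)CC2)nc2ccc(NC(=O)COc3ccc(Cl)cc3)cc12`, is reached from compound 2 by the change (tert-butyl in place of methyl on a saturated chain carbon bound to an amine nitrogen in a ring). For the measured compounds named here, no measured pair shows this kind of change here, so the size of the step in this assay cannot be read from the data; the expectation is a step of modest size, probably no larger than the usual scatter, in either direction. Compound 1 is the only measured point of reference, and compound 3 is therefore expected near 110 nM, within a range of 30 nM to 450 nM.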

Compound 3, half-maximal inhibitory concentration: 246 nM
For compound 3 the middle estimate is 2.2-fold (0.35 log units) below the measured one; measured number inside the range.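

In this assay, neopentyl in place of oxan-4-yl on an amine nitrogen in a ring gives a 2.1-fold higher number from compound 1 to compound 3 (0.33 log units; beyond the scatter), a modest step that lies beyond the scatter. For the compounds shown here, this is the first readable comparison at this position: the group placed there does change the read-out, yet with the open-chain neopentyl group compound 3 still gives a number on the same scale, so replacing the ring does not abolish inhibition. Nothing measured here gives a reason for this step.

On these data alone, compound 2 has no number, so the step from ethyl to neopentyl cannot be read, and the effect of chain size alone stays unknown. Also open, as far as these compounds go, is whether the ring or its oxygen matters more, which a cyclohexyl group or a 2-methoxyethyl chain in the same place could separate.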